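From 4-chlorophenyl to 3-chlorophenyl on the shared core

A few compounds are considered here, and "the series" means these few. Any claim that something is new, unique, unknown or untested is made for them only; others in the source may bear on it.

In a functional assay on Caco-2 cells (Homo sapiens) for inhibition, read by MTT assay, with a stated time of 48 h (on this read-out lower numbers stand for stronger inhibition of growth and higher numbers for weaker inhibition of growth), compound 1 `CN1CC[C@H](c2c(O)cc(O)c3c(=O)cc(/C=C/c4ccccc4)oc23)[C@H](O)C1` gives 3700 nM and compound 2 `CN1CC[C@H](c2c(O)cc(O)c3c(=O)cc(/C=C/c4ccc(Cl)cc4)oc23)[C@H](O)C1` gives 5600 nM so compound 2 stands within the scatter of compound 1. Compound 3 `CN1CC[C@H](c2c(O)cc(O)c3c(=O)cc(/C=C/c4cccc(Cl)c4)oc23)[C@H](O)C1` differs from compound 2 by 3-chlorophenyl in place of 4-chlorophenyl on a double-bonded chain carbon bound to a double-bonded chain carbon. Among the measured compounds shown here, the only measured step that bears on this is a 1.5-fold higher number from compound 1 to compound 2 (0.18 log units; within the scatter) and it is chloro in place of hydrogen on an aromatic carbon. On that evidence no step beyond the scatter is expected in this assay here. The estimated step is a 1.2-fold lower number from compound 2 to compound 3 (0.07 log units; within the scatter) and lies within the scatter. Compound 3 is estimated at 4800 nM with an expected range from 2400 nM to 9500 nM in this measurement.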

Compound 3, concentration for 50% growth inhibition: 9000 nM
Compound 3: the middle estimate sits 1.9-fold (0.27 log units) below what was measured; measured number inside the range.
By their numbers in this assay, from the lowest: compounds 1, 2 and 3 (each within the scatter of the next, the first and the last beyond it).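

In this assay, 3-chlorophenyl in place of 4-chlorophenyl gives a 1.6-fold higher number from compound 2 to compound 3 (0.21 log units; within the scatter), so the two chlorophenyl compounds are not separated by this change. Chloro in place of hydrogen on an aromatic carbon, however, now gives a 2.4-fold higher number from compound 1 to compound 3 (0.39 log units; beyond the scatter), a modest step towards weaker inhibition of growth and the first one in this set to pass the scatter. No measurement here accounts for this step. The compounds shown leave open whether fluoro, methoxy or an amine in place of the chloro would give a similar step. They also leave open whether a carboxylic acid there would reverse its direction.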